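Working notes: dimethylcarbamoyl to 5-methoxypyridin-2-yl on the five-membered ring

The source may report more compounds than this note shows. Statements on the series, on what has been measured and on what is new or still open speak of the compounds shown alone.

compound 1 `O=C(CCCCCCc1ccccc1)c1nnc(-c2ccccc2)[nH]1`: > 10000 nM
compound 2 `CN(C)C(=O)c1cnc(C(=O)CCCCCCc2ccccc2)o1`: > 10000 nM

Compound 1 returns only a limit in an assay on HEK-293T cells for inhibition of diacylglycerol lipase-alpha (Homo sapiens), read by colorimetric assay (on this read-out lower numbers stand for stronger inhibition and higher numbers for weaker inhibition), namely > 10000 nM. Compound 2 likewise returns only a limit, > 10000 nM; it stands at the limit of > 10000 nM in this assay, at which 2 of the 2 values shown sit, so no number places it against compound 1. Compound 3 `COc1ccc(-c2cnc(C(=O)CCCCCCc3ccccc3)o2)nc1` differs from compound 2 by 5-methoxypyridin-2-yl in place of dimethylcarbamoyl on an aromatic carbon. Among the compounds with values here, no measured step anchors this change, and with compound 2 at a limit no direction can be read from the values shown; any step is expected to stay within the scatter or remain unresolved. Compound 3 is therefore estimated at about 15000 nM, in the range 2500 nM to 100000 nM. The implied step that the limit leaves unreadable from compound 2 to compound 3 is expected to be small or undetectable.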

Compound 3, half-maximal inhibitory concentration: > 10000 nM
Compound 3: a limit, no number; the forecaster's own chance of this, stated with the estimate: 65%; the middle value is on the limit's open side.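

No step from compound 2 to compound 3 can be read, since both return only a limit: the limit of > 10000 nM in this assay, at which 3 of the 3 values shown sit.

The compounds shown leave open how strongly any of them inhibits in this assay, and whether the group change matters at all.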